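A few compounds are considered here, and "the series" means these few. Any claim that something is new, unique, unknown or untested is made for them only; others in the source may bear on it.

Measured in an assay on ileum with histamine H1 receptor (Cavia porcellus) as the target; a higher number here means a weaker inhibitor, a lower number a stronger inhibitor:
compound 1 `CCc1ccccc1NC(=O)CCN1CCC(Cc2ccccc2)CC1`, 477 nM
compound 2 `O=C(CCN1CCC(Cc2ccccc2)CC1)Nc1ccccc1Cl`, 561 nM
compound 3 `O=C(CCN1CCC(Cc2ccccc2)CC1)Nc1ccccc1F`, 832 nM

Compound 3 carries the largest of these three numbers, but the steps of a 1.7-fold higher number from compound 1 to compound 3 (0.24 log units; within the scatter) and a 1.5-fold higher number from compound 2 to compound 3 (0.17 log units; within the scatter) both lie within the scatter, as does a 1.2-fold higher number from compound 1 to compound 2 (0.07 log units; within the scatter), so the three compounds cannot be told apart on these data.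

Compound 4 `O=C(CCN1CCC(Cc2ccccc2)CC1)Nc1ccccc1` differs from compound 3 by hydrogen in place of fluoro on an aromatic carbon. Among the measured compounds shown here, no measured step removes the group at this position altogether; the steps that bear on it only exchange one group for another there, and every one of them stays within the scatter. For compound 4 the step is therefore expected to be small, a 1.2-fold lower number from compound 3 to compound 4 (0.08 log units; within the scatter). Compound 4 in this assay is estimated at 700 nM, with a range of 300 nM to 1800 nM.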

Compound 4, half-maximal inhibitory concentration: 1510 nM
Compound 4: the middle estimate sits 2.2-fold (0.33 log units) below what was measured; the measured number falls inside the stated range.
By their numbers in this assay, from the lowest: compounds 1, 2, 3 and 4 (each within the scatter of the next, the first and the last beyond it).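

In this assay, among the compounds shown here, taking the group off this aromatic carbon, ortho to a large group, gives the first steps beyond the scatter: a 2.7-fold higher number from compound 2 to compound 4 (0.43 log units; beyond the scatter) and a 3.2-fold higher number from compound 1 to compound 4 (0.50 log units; beyond the scatter), where exchanges among ethyl, chloro and fluoro gave none. The loss is not uniform, since a 1.8-fold higher number from compound 3 to compound 4 (0.26 log units; within the scatter) stays within the scatter, so hydrogen separates from chloro and ethyl but not from fluoro. Nothing at hand accounts for this difference.

Open, from the compounds shown here alone, is whether a methoxy group, an amine or a longer chain at this place would give numbers like those of compound 1 and compound 2 or like that of compound 4.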